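The source may report more compounds than this note shows. Statements on the series, on what has been measured and on what is new or still open speak of the compounds shown alone.

Measured compounds and values

compound 1, `Cc1ccccc1S(=O)(=O)NC(=O)c1ccc(Nc2nc(NC3(c4ccc(Cl)cc4)CC3)nc(OCC(F)(F)F)n2)cc1`: 265 nm/s
compound 2, `CC(C)C(=O)NCCS(=O)(=O)NC(=O)c1ccc(Nc2nc(NC3(c4ccc(Cl)cc4)CC3)nc(OCC(F)(F)F)n2)cc1`: 13 nm/s
compound 3, `CC(C)S(=O)(=O)NC(=O)c1ccc(Nc2nc(NC3(c4ccc(Cl)cc4)CC3)nc(OCC(F)(F)F)n2)cc1`: 31 nm/s

The account concerns a physicochemical assay for permeability, using PAMPA, at pH 7.4; a higher number here means that the compound crosses the layer faster, a lower number that the compound crosses the layer more slowly. Among the three measured compounds, compound 1 stands highest; its nearest neighbour is compound 3, and compound 2 lies furthest from it. Both measured steps away from compound 1 go down: a 20-fold lower number from compound 1 to compound 2 (1.31 log units; beyond the scatter) and an 8.5-fold lower number from compound 1 to compound 3 (0.93 log units; beyond the scatter). Between the two lower compounds, a 2.4-fold higher number from compound 2 to compound 3 (0.38 log units; beyond the scatter).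

Compound 4, `O=C(NS(=O)(=O)c1ccc(F)cc1)c1ccc(Nc2nc(NC3(c4ccc(Cl)cc4)CC3)nc(OCC(F)(F)F)n2)cc1`, has not yet been measured in this assay. It differs from compound 1 in one place: 4-fluorophenyl in place of 2-methylphenyl on a sulfonyl sulfur

The two measured steps from compound 1 both exchange the 2-methylphenyl on the sulfonyl sulfur for a group without an aromatic ring, and both steps are large or modest downward movements. The step to compound 4 is of a different kind: one six-membered aromatic ring of carbon only is kept, and only the substituent on that ring changes. For the measured compounds named here, no measured pair shows such an aryl-to-aryl exchange, so the measured steps set only a loose bound. The change is therefore expected to move the number of compound 4 little, most likely within the scatter or a small decrease, a 1.3-fold lower number from compound 1 to compound 4 (0.12 log units; within the scatter). Compound 4 is accordingly estimated at 200 nm/s, within a range from 90 nm/s to 420 nm/s.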

Compound 4, apparent permeability: 193 nm/s
Compound 4: middle estimate off by 1.0-fold (0.02 log units), on the high side, within the range that was stated.
By their numbers in this assay, from the lowest: compound 2; then compound 3; then compounds 4 and 1 (each within the scatter of the next).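

In this assay, the exchange of 2-methylphenyl for 4-fluorophenyl on the sulfonyl sulfur gives a 1.4-fold lower number from compound 1 to compound 4 (0.14 log units; within the scatter), so this position now has a pair in which one six-membered aromatic ring of carbon only is kept and only its substituent changes, and that change leaves a step within the scatter. The groups without an aromatic ring stand apart from 4-fluorophenyl as they do from 2-methylphenyl, with a 6.2-fold higher number from compound 3 to compound 4 (0.79 log units; beyond the scatter) and a 15-fold higher number from compound 2 to compound 4 (1.17 log units; beyond the scatter), so among these four compounds the two with an aromatic ring on the sulfonyl sulfur both give higher numbers than the two without, and none of the four goes against this. No measurement is available that would explain this pattern.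

The compounds shown leave open whether the pattern depends on the aromatic ring itself or on the size of the group, which a cyclohexyl group on the sulfonyl sulfur would help to separate. They also leave open how an unsubstituted phenyl, or a pyridyl ring with nitrogen in the ring, would compare with 2-methylphenyl and 4-fluorophenyl at this position.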